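The compounds below may be only part of what the source reports. "The series", "measured", "known", "first", "only" and "open" are said of these compounds alone.

Compound 1 `COc1ccc([C@H]2SCC(=O)N2NC(=O)c2nccnc2N)cc1OC`: 86.2 ug/mL
Compound 2 `Cc1cnc(C(=O)NN2C(=O)CS[C@@H]2c2ccc([N+](=O)[O-])cc2)cn1`: > 100 ug/mL
Compound 3 `CCOc1cc([C@@H]2SCC(=O)N2NC(=O)c2cnc(C)cn2)ccc1O`: > 100 ug/mL

All three were tested in an ADME assay on MCF7 cells (Homo sapiens) for cytotoxicity, read by MTT assay, with a stated time of 4 days; on this read-out lower numbers stand for stronger inhibition and higher numbers for weaker inhibition. Compound 1 gives a measured number, 86.2 ug/mL. For compound 2 the result > 100 ug/mL is a limit of the assay, not a number. Compound 3 likewise shows only a limit, > 100 ug/mL. Compound 2 therefore sits at the limit of > 100 ug/mL in this assay, at which 2 of the 3 values shown sit, with no measurable effect on the cells up to that point.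

Compound 4 `O=C(NN1C(=O)CS[C@@H]1c1ccc([N+](=O)[O-])cc1)c1cnccn1` has not yet been measured. It differs from compound 2 by hydrogen in place of methyl on an aromatic carbon. Going by the values given here, no measured pair shows what this change does, so in this assay no step beyond the usual scatter is expected. The step is expected to be a step that the limit leaves unreadable from compound 2 to compound 4. Compound 4 is therefore estimated at 120 ug/mL, most likely between 60 ug/mL and 300 ug/mL, and quite possibly again reported only as a limit.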

Compound 4, half-maximal inhibitory concentration: 65.6 ug/mL
Compound 4: the middle estimate sits 1.8-fold (0.26 log units) above what was measured, within the range that was stated.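

In this assay, going by these compounds alone, the new pair gives an at least 1.5-fold lower number from compound 2 to compound 4 (0.18 log units; that floor lies within the scatter) for hydrogen in place of methyl on this aromatic carbon, the only step at this position that can be read. From the compounds shown here alone, compound 2 carries only a limit, so the true size of the step is unknown: it may be large, or no real change at all. Compound 4 does show that pyrazin-2-yl, in place of 5-methylpyrazin-2-yl, gives a measured number.

Going by these compounds, what a carboxylic acid or a longer chain would do at this position stays open. So does whether the same change acts alike when the other parts of the molecule differ.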